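The compounds below may be only part of what the source reports. "The series", "measured", "known", "first", "only" and "open" are said of these compounds alone.

Compound 1 `Oc1cccc(-c2cc(-c3cccs3)cc(-c3ccccc3O)n2)c1` is measured in a functional assay on DU-145 cells (Homo sapiens) for cytotoxicity, read by CCK-8 assay (a lower number here means a stronger inhibitor, a higher number a weaker inhibitor), where compound 1 gives 9300 nM. Compound 2 `Oc1ccc(-c2cc(-c3cccs3)cc(-c3ccccc3O)n2)cc1` differs from it by 4-hydroxyphenyl in place of 3-hydroxyphenyl on an aromatic carbon. In this assay compound 2 reaches only a limit of the assay and gives > 50000 nM. The step is therefore known only as a lower bound: an at least 5.3-fold higher number from compound 1 to compound 2 (0.73 log units; beyond the scatter). That the result is a limit is shown by the limit of > 50000 nM in this assay, at which 1 of the 3 values shown sits.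

Compound 3 `Oc1ccc(-c2cc(-c3ccccn3)cc(-c3cccc(O)c3)n2)cc1` has a different core, and the difference between the two cores is not broken down here. In this assay compound 3 gives 1980 nM, the lowest of the two numbers recorded, with compound 1 standing a good way higher.

Compound 4 `Oc1ccc(-c2cc(-c3ccccn3)cc(-c3ccc(O)cc3)n2)cc1` has not yet been measured. It differs from compound 3 by 4-hydroxyphenyl in place of 3-hydroxyphenyl on an aromatic carbon. This is the same kind of change as that from compound 1 to compound 2, but not the same change: in the first pair the place is meta to a 2-hydroxyphenyl group and meta to a thiophen-2-yl group, whereas here it is meta to a 4-hydroxyphenyl group and meta to a pyridin-2-yl group. On the strength of the weakening seen in an at least 5.3-fold higher number from compound 1 to compound 2 (0.73 log units; beyond the scatter), a weakening of similar size is expected here, a 6.1-fold higher number from compound 3 to compound 4 (0.78 log units; beyond the scatter). Compound 4 is accordingly estimated at 12000 nM in this assay, with a likely range from 4000 nM to 50000 nM.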

Compound 4, half-maximal inhibitory concentration: > 50000 nM
Compound 4: only a limit was reported; the forecaster's own chance of this, stated with the estimate: 20%; at least 4.1-fold (0.61 log units) between middle value and limit.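

In this assay compound 4 reaches only a limit of the assay, > 50000 nM. Putting 4-hydroxyphenyl in place of 3-hydroxyphenyl gives an at least 25-fold higher number from compound 3 to compound 4 (1.40 log units; beyond the scatter), which runs in the same direction as the step on the core of compound 1, so in the two pairs shown the weakening carries over from one core to the other: the same change on two cores in this assay, an at least 5.3-fold higher number (0.73 log units; beyond the scatter) from compound 1 to compound 2 and an at least 25-fold higher number (1.40 log units; beyond the scatter) from compound 3 to compound 4; the limit leaves it open whether they differ What this does not show is how large the weakening really is on either core, or whether it is larger on one than on the other, as each step is only a lower bound set by the same limit: the limit of > 50000 nM in this assay, at which 2 of the 4 values shown sit.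

The compounds shown leave open whether the hydroxyl of the 3-hydroxyphenyl group is itself needed, as a methoxy group, an amine or a carboxylic acid at that place in compound 3 would be required to tell. They also leave open whether the same change would weaken compounds on a core carrying a group other than thiophen-2-yl or pyridin-2-yl, such as a plain phenyl or a longer alkyl chain, so two pairs give the direction of the change only for these two cores.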